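The compounds below may be only part of what the source reports. "The series", "measured", "known", "first", "only" and "open" are said of these compounds alone.

Measured so far:
compound 1 `Cc1c(OCCCCOc2ccc(C(=O)O)cc2F)ccc(C(=O)CC2CCCC2)c1O`: 639 nM
compound 2 `Cc1c(OCCCCOc2ccc(C(=O)O)cc2F)ccc(C(=O)CC(C)C)c1O`: 102 nM

In an assay on HEK293 cells for positive allosteric modulation of metabotropic glutamate receptor 2 (Rattus norvegicus), read by thallium flux, with a stated time of 2.5 min (on this read-out lower numbers stand for an effect already at smaller amounts and higher numbers for an effect only at larger amounts of compound), compound 1 gives 639 nM, the highest of the two numbers. Compound 2 gives 102 nM. Among the compounds with values here, the one measured step is a 6.3-fold lower number from compound 1 to compound 2 (0.80 log units; beyond the scatter), a change on the carbonyl side of the shared core. Compound 3 `COc1ccc(C(=O)O)cc1OCCCCOc1ccc(C(=O)CC2CCCC2)c(O)c1C` differs from compound 1 elsewhere: 5-carboxy-2-methoxyphenyl in place of 4-carboxy-2-fluorophenyl on an oxygen on a saturated carbon. Within the data shown here, no measured step touches this phenyl, so nothing measured bears on the change, and no step beyond the scatter is expected in this assay, though the uncertainty is wide. Compound 3 is therefore estimated at 700 nM, within 200 nM to 2500 nM. That estimate means an expected step of a 1.1-fold higher number from compound 1 to compound 3 (0.04 log units; within the scatter).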

Compound 3, half-maximal effective concentration: 425 nM
Estimate against measurement, compound 3: 1.6-fold (0.22 log units) above; the measured number falls inside the stated range.
By their numbers in this assay, from the lowest: compound 2; then compounds 3 and 1 (each within the scatter of the next).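

In this assay, 5-carboxy-2-methoxyphenyl in place of 4-carboxy-2-fluorophenyl gives a 1.5-fold lower number from compound 1 to compound 3 (0.18 log units; within the scatter), so this group on the oxygen could be exchanged without a step beyond the scatter. No measurement is at hand to explain this result.

This exchange alters the fluoro, the methoxy and the carboxy placement together, so the compounds shown cannot separate their contributions. Going by these compounds, it also remains open whether a tetrazole could stand in for the carboxylic acid, and whether 5-carboxy-2-methoxyphenyl would give a similar result alongside the isopropyl of compound 2.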